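This account rests on a few compounds, and the source may have more. Where it says the series, first, only, none or still open, it means among the compounds named here.

Measured compounds:
Compound 1, `CCn1c(C(=O)N(C)c2ccccc2)ccc1C(CC)(CC)c1ccc(OCC(=O)C(C)(C)C)c(C)c1`: 18500 nM in an assay on HL-60 cells for agonist activity at vitamin D3 receptor (Homo sapiens), read by microscopy, with a stated time of 96 h; on this read-out higher numbers stand for an effect only at larger amounts of compound and lower numbers for an effect already at smaller amounts
Compound 2, `C#CCNC(=O)c1ccc(C(CC)(CC)c2ccc(OCC(O)C(C)(C)C)c(C)c2)n1CC`: 240 nM in this assay

Of the two numbers in this assay, compound 2 stands at the lower one, and the gap up to compound 1 lies well beyond the usual scatter of repeated measurements. Within the data shown here, compound 1 and compound 2 differ in more than one place, so their two values show only that compound 2 is the more potent of the pair in this assay and nothing about any single change.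

Compound 3, `CCn1c(C(=O)Nc2cccc(C(F)(F)F)c2)ccc1C(CC)(CC)c1ccc(OCC(O)C(C)(C)C)c(C)c1`, has not yet been measured. It differs from compound 2 in one place: 3-(trifluoromethyl)phenyl in place of propargyl on an amide-type nitrogen. The hydroxyl-bearing side chain of compound 2 is kept. Among the measured compounds shown here, no measured pair isolates this change, so the expectation rests on compound 2 alone. The step from compound 2 to compound 3 in this assay is expected to be a 2.9-fold higher number from compound 2 to compound 3 (0.46 log units; beyond the scatter), toward a higher number, somewhat beyond the scatter. Compound 3 is estimated at 700 nM in this assay, with a likely range from 150 nM to 3500 nM.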

Compound 3, half-maximal effective concentration: > 50000 nM
Compound 3 gave a limit, no number; the forecaster's own chance of this, stated with the estimate: 5%; at least 71-fold (1.85 log units) between middle value and limit.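

At the amide-type nitrogen, with the hydroxyl-bearing side chain kept, putting 3-(trifluoromethyl)phenyl in place of propargyl gives an at least 200-fold higher number from compound 2 to compound 3 (2.31 log units; beyond the scatter) in this assay. For compound 3 the reading is a limit of the assay and not a number: the limit of > 50000 nM in this assay, at which 1 of the 3 values shown sits. The earlier pair could not speak to any single change, as compound 1 and compound 2 differ in more than one place, whereas this pair shows that the group on this nitrogen can, on its own, move the read-out far beyond the scatter, and that the hydroxyl-bearing side chain does not protect against this loss when this group is exchanged.

A single exchange cannot tell whether the step comes with the phenyl ring itself or with the trifluoromethyl on it, and a plain phenyl on this nitrogen would separate the two. Equally open, from the compounds shown here alone, is how the read-out responds to other groups here, such as a short saturated chain like ethyl or propyl, which would show whether the triple bond of propargyl matters or a small chain of the same length serves as well.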